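The source may hold more compounds than are shown below. What is called first, only, known or untested is meant among the compounds shown, and "the series" means these compounds.

Working notes on the series. The shared core of compound 1 `C1CCC(c2nnc3nnc(N4CCCC4)nn23)CC1` carries cyclohexyl on an aromatic carbon; in a functional assay on MCF7 cells (Homo sapiens) for cytotoxicity, read by MTT assay, with a stated time of 72 h (a higher number here means a weaker inhibitor, a lower number a stronger inhibitor), compound 1 gives 37700 nM. Compound 2 `CCCCCc1nnc2nnc(N3CCCC3)nn12` gives 42900 nM and compound 3 `Clc1ccccc1-c1nnc2nnc(N3CCCC3)nn12` gives 29600 nM, so compound 3 sits within the scatter of both neighbours: a 1.3-fold lower number from compound 1 to compound 3 (0.11 log units; within the scatter) and a 1.4-fold lower number from compound 2 to compound 3 (0.16 log units; within the scatter), as does a 1.1-fold higher number from compound 1 to compound 2 (0.06 log units; within the scatter). Compound 4 `CCc1nnc2nnc(N3CCCC3)nn12` differs from compound 3 by ethyl in place of 2-chlorophenyl on an aromatic carbon. Going by the values given here, the steps that bear on it are the exchanges of cyclohexyl, pentyl and 2-chlorophenyl on that carbon, none of which moved the number beyond the scatter, so no step beyond the scatter is expected in this assay for ethyl either. Compound 4 is therefore estimated at 36000 nM, range 15000 nM to 85000 nM, an expected step of a 1.2-fold higher number from compound 3 to compound 4 (0.09 log units; within the scatter).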

Compound 4, half-maximal inhibitory concentration: 47000 nM
Compound 4: middle estimate off by 1.3-fold (0.12 log units), on the low side, within the range that was stated.
By their numbers in this assay, from the lowest: compounds 3, 1, 2 and 4 (each within the scatter of the next).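

In this assay, ethyl on this aromatic carbon, with no ring, replaces the 2-chlorophenyl ring with only a small step: a 1.6-fold higher number from compound 3 to compound 4 (0.20 log units; within the scatter). The chain exchange gives a 1.1-fold higher number from compound 2 to compound 4 (0.04 log units; within the scatter) and ethyl in place of cyclohexyl gives a 1.2-fold higher number from compound 1 to compound 4 (0.10 log units; within the scatter), so neither removing the ring nor changing the chain separates these four compounds at this position. No supporting data bear on this flat result. On these data alone, whether an amine or a carboxylic acid on this carbon would move the number beyond the scatter stays open, as does any change elsewhere on the shared core.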